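A few compounds are considered here, and "the series" means these few. Any claim that something is new, unique, unknown or untested is made for them only; others in the source may bear on it.

Measured so far:
compound 1, `Fc1ccc(C2CCN(c3ccn4c(CC5CC5)nnc4c3Cl)CC2)c(F)c1`: 61.7 nM
compound 2, `COc1ccc(F)cc1C1CCN(c2ccn3c(CC4CC4)nnc3c2Cl)CC1`: 8.2 nM
compound 3, `COc1c(F)cccc1C1CCN(c2ccn3c(CC4CC4)nnc3c2Cl)CC1`: 37 nM

All three share one core and differ only in the aromatic group on a saturated ring carbon. In a functional assay on CHO cells for agonist activity at metabotropic glutamate receptor 2 (Homo sapiens), read by scintillation counting and GTPgammaS binding, with a stated time of 30 min (a higher number here means that more compound is needed for the effect, a lower number that less compound is needed), compound 3 gives the second highest of the three numbers: it sits within the scatter of compound 1 (a 1.7-fold lower number from compound 1 to compound 3 (0.22 log units; within the scatter)) but clearly apart from compound 2 (a 4.5-fold higher number from compound 2 to compound 3 (0.65 log units; beyond the scatter)).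

Compound 4, `COc1ccc(F)c(F)c1C1CCN(c2ccn3c(CC4CC4)nnc3c2Cl)CC1`, has not yet been measured. It differs from compound 3 in one place: 2,3-difluoro-6-methoxyphenyl in place of 3-fluoro-2-methoxyphenyl on a saturated ring carbon. The new group carries one fluorine more than the one it replaces and, read around the ring the other way, holds the same fluorine and methoxy arrangement as the 5-fluoro-2-methoxyphenyl of compound 2 with an added fluorine.

The relevant steps are a 7.5-fold lower number from compound 1 to compound 2 (0.88 log units; beyond the scatter) and a 4.5-fold higher number from compound 2 to compound 3 (0.65 log units; beyond the scatter), both modest and beyond the scatter, and both favouring the pattern found in compound 2. On that basis a lower number in this assay is expected for compound 4, a 2.6-fold lower number from compound 3 to compound 4 (0.42 log units; beyond the scatter), roughly landing near compound 2. The estimate for compound 4 in this assay is 14 nM, with a likely range from 5 nM to 45 nM.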

Compound 4, half-maximal effective concentration: 9.3 nM
Compound 4: the middle estimate sits 1.5-fold (0.18 log units) above what was measured, and the stated range covers the measured number.
By their numbers in this assay, from the lowest: compounds 2 and 4 (each within the scatter of the next); then compounds 3 and 1 (each within the scatter of the next).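

In this assay, fluoro in place of hydrogen on an aromatic carbon of the 5-fluoro-2-methoxyphenyl group gives no readable change (a 1.1-fold higher number from compound 2 to compound 4 (0.05 log units; within the scatter)), so this ring position accepts a fluorine without the number leaving the scatter. The fluorine and methoxy arrangement that set the low number apart earlier therefore holds with an added fluorine, and the 2,3-difluoro-6-methoxyphenyl group stands clearly apart from both the 3-fluoro-2-methoxyphenyl group (a 4.0-fold lower number from compound 3 to compound 4 (0.60 log units; beyond the scatter)) and the 2,4-difluorophenyl group (a 6.6-fold lower number from compound 1 to compound 4 (0.82 log units; beyond the scatter)). Nothing measured here bears on the reason for these differences.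

The compounds shown leave open whether this aromatic carbon also accepts a group larger than fluoro, such as chloro, methyl or nitrile, since fluoro is the only replacement for hydrogen at this place. They also leave open how the number responds when the methoxy of the 2,3-difluoro-6-methoxyphenyl group gives way to a hydroxyl or an ethoxy while both fluorines stay in place.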